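Swapping the carboxyethyl tail of compound 3 for an aminocyclopentyl ring

The source may hold more compounds than are shown below. What is called first, only, known or untested is meant among the compounds shown, and "the series" means these compounds.

Three compounds share one core and differ only in the group carried on an aromatic nitrogen. Compound 1 `NCc1ccc(-n2cc(-c3ccc4cc[nH]c4c3)c(C(F)(F)F)n2)cc1` is the strongest of the three: in an assay on isolated protein for inhibition of Myeloperoxidase (Homo sapiens) (a higher number here means a weaker inhibitor, a lower number a stronger inhibitor), compound 1 gives 30 nM. Compound 2 `NC(=O)CCn1cc(-c2ccc3cc[nH]c3c2)c(C(F)(F)F)n1` gives 4200 nM in this assay, and compound 3 `O=C(O)CCn1cc(-c2ccc3cc[nH]c3c2)c(C(F)(F)F)n1` gives 5200 nM, the highest number of the three, although the gap between compound 2 and compound 3 is within the scatter, as shown by a 1.2-fold higher number from compound 2 to compound 3 (0.09 log units; within the scatter).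

Compound 4 `N[C@@H]1CC[C@@H](n2cc(-c3ccc4cc[nH]c4c3)c(C(F)(F)F)n2)C1` is not yet measured. It differs from compound 3 in one place: a group of 6 heavy atoms (5 carbon, 1 nitrogen; one five-membered non-aromatic ring of carbon only) in place of a group of 5 heavy atoms (3 carbon, 2 oxygen; no ring), on an aromatic nitrogen. The incoming group, like the 4-(aminomethyl)phenyl of compound 1, carries one nitrogen and has a ring, whereas the carboxyethyl it replaces has neither. Going by the values given here, the steps that bear on this are a 170-fold higher number from compound 1 to compound 3 (2.24 log units; beyond the scatter) and a 140-fold higher number from compound 1 to compound 2 (2.15 log units; beyond the scatter), both large. On that basis compound 4 is expected to move back toward compound 1, so the estimated step is a 35-fold lower number from compound 3 to compound 4 (1.54 log units; beyond the scatter), a large drop. Compound 4 is therefore estimated at 150 nM in this assay, within a range of 30 nM to 800 nM.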

Compound 4, half-maximal inhibitory concentration: 70 nM
For compound 4 the middle estimate is 2.1-fold (0.33 log units) above the measured one; the range from low to high includes it.
By their numbers in this assay, from the lowest: compound 1; then compound 4; then compounds 2 and 3 (each within the scatter of the next).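

Placed on this aromatic nitrogen in this assay, the ring bearing an amine gives a far lower number than either open chain, both steps being large (a 74-fold lower number from compound 3 to compound 4 (1.87 log units; beyond the scatter); a 60-fold lower number from compound 2 to compound 4 (1.78 log units; beyond the scatter)). An aromatic ring on this nitrogen is thus not needed for a number near that of compound 1, although the 4-(aminomethyl)phenyl group keeps a modest edge (a 2.3-fold higher number from compound 1 to compound 4 (0.37 log units; beyond the scatter)). No measurement shown here accounts for these differences.

Compound 4 changes the ring and the amine together, so a plain cyclopentyl group and an open chain ending in an amine, such as 3-aminopropyl, would be needed to separate their contributions. The other stereoisomers of the aminocyclopentyl group also leave open whether its two defined stereocentres matter here.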